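Swapping pyridin-3-yl for pyridin-4-yl on compound 1

This account rests on a few compounds, and the source may have more. Where it says the series, first, only, none or still open, it means among the compounds named here.

Compound 1 `CC(C)C(C)(C)/N=C(\NC#N)Nc1cccnc1` is the reference point of this series. In a functional assay on the whole organism (blood, strain Wistar-Okamoto) with Rattus norvegicus as the target, with a stated time of 5 days (a higher number here means that more compound is needed for the effect, a lower number that less compound is needed), compound 1 gives 1 mg/kg, the lowest number among the three compounds measured, so the least compound is needed for its effect. Compound 2 `CC(C)(C)CC(C)(C)/N=C(\NC#N)Nc1cccnc1` gives 50 mg/kg and compound 3 `N#CN/C(=N\CC1CCCO1)Nc1cccnc1` gives 50 mg/kg. Both steps away from compound 1, a 50-fold higher number from compound 1 to compound 2 (1.70 log units; beyond the scatter) and a 50-fold higher number from compound 1 to compound 3 (1.70 log units; beyond the scatter), are large, and both concern the group sitting on the double-bonded nitrogen. Compound 4 `CC(C)C(C)(C)/N=C(\NC#N)Nc1ccncc1` leaves that group untouched and instead alters the aromatic ring: pyridin-4-yl in place of pyridin-3-yl on an amine nitrogen. For the measured compounds named here, neither measured step touches this part of the shared core, so no step among the measured compounds bears on the change, and nothing in the data argues for a shift in either direction. The expectation for compound 4 is therefore a step that stays within the scatter, no change at the digits printed from compound 1 to compound 4 (within the scatter). On that basis compound 4 is estimated at 1 mg/kg, with a range from 0.3 mg/kg to 3 mg/kg.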

Compound 4, minimum effective dose: 20 mg/kg
The estimate for compound 4 lay 20-fold (1.30 log units) below the measured number; the whole stated range lies below it.
By their numbers in this assay, from the lowest: compound 1; then compound 4; then compounds 2 and 3 (each within the scatter of the next).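

For the compounds shown here, the step of a 20-fold higher number from compound 1 to compound 4 (1.30 log units; beyond the scatter) in this assay shows that the aromatic ring on the amine nitrogen is not a neutral part of the molecule, which the earlier steps could not reveal because both concerned the group on the double-bonded nitrogen. Pyridin-3-yl and pyridin-4-yl have the same heavy atoms and the same counts of donors and acceptors, so a change in how the same atoms are joined is enough to produce a large step. No measurement shown here explains this difference.

The compounds shown leave open how pyridin-2-yl or a plain phenyl ring would compare with pyridin-3-yl on the amine nitrogen. From the compounds shown here alone, it also remains open whether pyridin-4-yl would produce a step of similar size alongside the neopentyl-bearing chain of compound 2.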